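Notes on compound 4: the methoxy taken away

A few compounds are considered here, and "the series" means these few. Any claim that something is new, unique, unknown or untested is made for them only; others in the source may bear on it.

For the measured compounds named here, the three compounds measured so far share one core and differ only in the aryl group carried on a nitrogen on an aromatic ring. Compound 1 `Cc1ccccc1Nc1nnc(Nc2nc(-c3ccc(Br)cc3)cs2)s1` gives 300 mg/kg in a functional assay on the whole organism (strain albino) with Mus musculus as the target, in the maximal electroshock model, with a stated time of 0.5 h; a higher number here means that more compound is needed for the effect, a lower number that less compound is needed. Compound 2 `Cc1ccc(Nc2nnc(Nc3nc(-c4ccc(Br)cc4)cs3)s2)cc1` gives 100 mg/kg in this assay, and compound 3 `COc1ccc(Nc2nnc(Nc3nc(-c4ccc(Br)cc4)cs3)s2)cc1` gives 30 mg/kg. Compound 3 thus stands at the lowest number of the three: the step of a 3.3-fold lower number from compound 2 to compound 3 (0.52 log units; beyond the scatter) and the step of a 10-fold lower number from compound 1 to compound 3 (1.00 log units; beyond the scatter) are both beyond the scatter, so within this set compound 3 needs the least material for the effect.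

Compound 4 `Brc1ccc(-c2csc(Nc3nnc(Nc4ccccc4)s3)n2)cc1` differs from compound 3 in one place: hydrogen in place of methoxy on an aromatic carbon. Going by the values given here, no measured pair removes a substituent from this ring altogether, so the nearest guides are a 3.3-fold lower number from compound 2 to compound 3 (0.52 log units; beyond the scatter), where methoxy in place of methyl brought the lower number, and a 10-fold lower number from compound 1 to compound 3 (1.00 log units; beyond the scatter). Both show the 4-methoxyphenyl group sitting at the lowest number, and taking the methoxy away is expected to move the number back up rather than down. For compound 4 the step is estimated as a 3.3-fold higher number from compound 3 to compound 4 (0.52 log units; beyond the scatter). Compound 4 is therefore expected to give about 100 mg/kg in this assay, with a range from 30 mg/kg to 300 mg/kg.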

Compound 4, minimum effective dose: 300 mg/kg
Compound 4: the middle estimate sits 3.0-fold (0.48 log units) below what was measured; the range from low to high includes it.
By their numbers in this assay, from the lowest: compound 3; then compound 2; then compounds 1 and 4 (each within the scatter of the next).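

In this assay the group on this aromatic carbon, para to a large group, carries real weight: the change to hydrogen gives a 10-fold higher number from compound 3 to compound 4 (1.00 log units; beyond the scatter) and so gives up the whole margin that compound 3 held over the rest of the set. The methyl at this same place counts as well: hydrogen in place of methyl gives a 3.0-fold higher number from compound 2 to compound 4 (0.48 log units; beyond the scatter) and completes an order at this place of methoxy, then methyl, then hydrogen, whereas the methyl as it stands in compound 1 offers nothing over hydrogen, the reading being no change at the digits printed from compound 1 to compound 4 (within the scatter) for that pair. Nothing on hand says what lies behind this order.

From the compounds shown here alone, only hydrogen, methyl and methoxy are seen at this place, so it stays open whether an ethoxy, a hydroxy or a dimethylamino group there would go lower than compound 3 or fall back toward compound 4. Going by these compounds, it also stays open whether the same order would hold with chlorine or hydrogen in place of the bromine on the other aryl ring.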